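This account rests on a few compounds, and the source may have more. Where it says the series, first, only, none or still open, it means among the compounds named here.

Working notes on the series. In a functional assay on 1A9 cells (Homo sapiens) for cytotoxicity (on this read-out higher numbers stand for an effect only at larger amounts of compound and lower numbers for an effect already at smaller amounts), compound 1 (`COC1=C(C)C(=O)/C(=C(O)/C=C/c2ccc(Br)cc2)C(=O)C1(C)C`) gives 1.1 ug/mL and compound 2 (`COC1=C(C)C(=O)/C(=C(O)/C=C/c2ccc(O)cc2)C(=O)C1(C)C`) gives 2.9 ug/mL. Compound 3 (`COC1=C(C)C(=O)/C(=C(O)/C=C/c2c(C)cccc2C)C(=O)C1(C)C`) has no number to anchor the step: its entry reads "not determined" (no result reported). Compound 4 (`COC1=C(C)C(=O)/C(=C(O)/C=C/c2c(C)cc(C)cc2C)C(=O)C1(C)C`) carries methyl in place of hydrogen on an aromatic carbon of compound 3: methyl in place of hydrogen on an aromatic carbon.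

For the measured compounds named here, only one measured step bears on this change, and only indirectly. It is a 2.6-fold higher number from compound 1 to compound 2 (0.42 log units; beyond the scatter), which exchanges bromo for hydroxy on an aromatic carbon, so it is a different substitution from the one at issue here. Going by the values given here, no measured step shows what a methyl does, and the direction stays open. A shift in this assay no larger than that modest step is expected, and with no value for compound 3 the estimate leans on compound 1 at 1.1 ug/mL and compound 2 at 2.9 ug/mL. The expected value for compound 4 is 2 ug/mL, with an estimated range from 0.7 ug/mL to 6 ug/mL.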

Compound 4, concentration for half-maximal effect: 6.2 ug/mL
The estimate for compound 4 lay 3.1-fold (0.49 log units) below the measured number; the measured number lies above the stated range.
By their numbers in this assay, from the lowest: compound 1; then compound 2; then compound 4.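

In this assay, for the compounds shown here, compound 4 gives 6.2 ug/mL but compound 3 has no number, so no step between compound 3 and compound 4 can be read. No supporting measurement bears on this result. From the compounds shown here alone, what methyl in place of hydrogen on an aromatic carbon does stays open.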